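This account rests on a few compounds, and the source may have more. Where it says the series, first, only, none or still open, it means among the compounds named here.

Measured so far in a functional assay on KYSE-450 cells (Homo sapiens) for inhibition, read by MTT assay, with a stated time of 48 h; on this read-out lower numbers stand for stronger inhibition and higher numbers for weaker inhibition:
- Compound 1 `C/C=C/C=C/C(=O)N(Cc1ccc(OC)c(O)c1)c1cc(OC)c(OC)c(OC)c1`: 180 nM
- Compound 2 `COc1ccc(CN(C(=O)CO)c2cc(OC)c(OC)c(OC)c2)cc1O`: 370 nM
- Compound 3 `C/C=C/C(=O)N(Cc1ccc(OC)c(O)c1)c1cc(OC)c(OC)c(OC)c1`: 67 nM

Compound 3 gives the lowest number of the three, and its steps to both others lie beyond the scatter. Compound 4 `COc1ccc(CN(C(=O)C2CC2)c2cc(OC)c(OC)c(OC)c2)cc1O` carries cyclopropyl in place of prop-1-en-1-yl on a carbonyl carbon. Among the compounds with values here, no measured step makes this exact swap. The closest evidence comes from changes in the group on that carbonyl carbon, which were all modest: a 2.7-fold lower number from compound 1 to compound 3 (0.43 log units; beyond the scatter) and a 5.5-fold lower number from compound 2 to compound 3 (0.74 log units; beyond the scatter). Both other groups gave higher numbers than compound 3 at 67 nM, so a small rise is expected in this assay. The expected step is a 1.6-fold higher number from compound 3 to compound 4 (0.22 log units; within the scatter). Compound 4 is estimated at 110 nM, with an expected range from 40 nM to 300 nM.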

Compound 4, half-maximal inhibitory concentration: 80 nM
Compound 4: middle estimate off by 1.4-fold (0.14 log units), on the high side; low and high end bracket the measured number.
By their numbers in this assay, from the lowest: compounds 3 and 4 (each within the scatter of the next); then compound 1; then compound 2.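

In this assay, the step of a 1.2-fold higher number from compound 3 to compound 4 (0.08 log units; within the scatter) shows that a three-membered ring of carbon can stand in for prop-1-en-1-yl on this carbonyl carbon, so the double bond of that chain is not required for a number this low. The steps of a 4.6-fold lower number from compound 2 to compound 4 (0.67 log units; beyond the scatter) and a 2.3-fold lower number from compound 1 to compound 4 (0.35 log units; beyond the scatter) show that cyclopropyl also keeps the advantage over hydroxymethyl and penta-1,3-dien-1-yl that prop-1-en-1-yl had. No measurement at hand explains this. On these data alone, whether cyclobutyl or a dimethylamino group on this carbonyl carbon would give a similar number remains open.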